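A few compounds are considered here, and "the series" means these few. Any claim that something is new, unique, unknown or untested is made for them only; others in the source may bear on it.

Compound 1 `N#C/C(=C\N1CCN(C(=O)c2ccco2)C1=S)C(=O)Nc1ccc(Cl)cc1` gives 25300 nM in a functional assay on IGROV-1 cells (Homo sapiens) for inhibition, read by sulforhodamine B assay, with a stated time of 48 h; on this read-out higher numbers stand for weaker inhibition of growth and lower numbers for stronger inhibition of growth.
Compound 2 `N#C/C(=C\N1CCN(C(=O)c2ccco2)C1=S)C(N)=O` gives 24000 nM in this assay.

Going by the values given here, compound 2 and compound 1 are the only two compounds measured, and their values sit within the scatter of each other, so neither can be placed ahead of the other. Among the compounds with values here, the step of a 1.1-fold lower number from compound 1 to compound 2 (0.02 log units; within the scatter) is the sole measured change, and it touched the amide-type nitrogen, not the carbonyl carbon.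

Compound 3 `N#C/C(=C\N1CCN(C(=O)c2ccco2)C1=S)C(=O)c1ccccc1` differs from compound 2 by phenyl in place of amino on a carbonyl carbon. Within the data shown here, no measured step bears on this position directly; the one step that is known, from compound 1 to compound 2, left the number essentially unchanged. On that footing the expected step of a 1.1-fold lower number from compound 2 to compound 3 (0.04 log units; within the scatter) is none beyond the scatter. Compound 3 is therefore estimated at 22000 nM in this assay, with a range from 7000 nM to 70000 nM.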

Compound 3, concentration for 50% growth inhibition: 19400 nM
Compound 3: the middle estimate sits 1.1-fold (0.05 log units) above what was measured; the measured number falls inside the stated range.
By their numbers in this assay, from the lowest: compounds 3, 2 and 1 (each within the scatter of the next).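

In this assay, benzoyl in place of carbamoyl gives a 1.2-fold lower number from compound 2 to compound 3 (0.09 log units; within the scatter), and phenyl in place of (4-chlorophenyl)amino on the same carbonyl carbon gives a 1.3-fold lower number from compound 1 to compound 3 (0.12 log units; within the scatter). The carbonyl carbon, on which no earlier step bore, thus accepts phenyl in place of either nitrogen-linked group with no shift beyond the scatter, and among these compounds a nitrogen on this carbon is not required to keep the number at this level. No measurement available here accounts for this flat result.

As far as these compounds go, whether a carboxylic acid, a methyl group or a longer alkyl chain on this carbonyl carbon would move the number beyond the scatter remains open. Also open, from the compounds shown here alone, is whether a change elsewhere on the shared core would shift the level at which all three compounds sit.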